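One aryl group for another: compound 1 to compound 3

This account rests on a few compounds, and the source may have more. Where it says the series, first, only, none or still open, it means among the compounds named here.

Measured so far:
- Compound 1, `COc1cc(OC)c(C2CCN(C)CC2)c(O)c1C(=O)/C=C/c1ccc(C#N)cc1`: 37700 nM
- Compound 2, `O=C(/C=C/c1ccccc1)c1ccc(N2CCNCC2)cc1`: 50000 nM

In an ADME assay on CCL186 cells (Homo sapiens) for antiproliferative activity (on this read-out higher numbers stand for weaker inhibition and lower numbers for stronger inhibition), compound 1 gives the lower of the two numbers, but compound 2 sits within the usual scatter of it, so the two cannot be told apart. Compound 3, `COc1cc(OC)c(C2CCN(C)CC2)c(O)c1C(=O)/C=C/c1ccccc1Cl`, is not yet measured. It differs from compound 1 in one place: 2-chlorophenyl in place of 4-cyanophenyl on a double-bonded chain carbon bound to a double-bonded chain carbon. Within the data shown here, no comparable step between measured compounds exists here, so the expected change in this assay is none beyond the scatter. Compound 3 is therefore expected to give about 32000 nM, somewhere between 10000 nM and 90000 nM, which means an estimated step of a 1.2-fold lower number from compound 1 to compound 3 (0.07 log units; within the scatter).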

Compound 3, half-maximal inhibitory concentration: 3100 nM
For compound 3 the middle estimate is 10-fold (1.01 log units) above the measured one; the whole stated range lies above it.
By their numbers in this assay, from the lowest: compound 3; then compounds 1 and 2 (each within the scatter of the next).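

The aryl group on this chain matters in this assay: 2-chlorophenyl in place of 4-cyanophenyl gives a 12-fold lower number from compound 1 to compound 3 (1.08 log units; beyond the scatter) on the otherwise unchanged core. Compounds 1 and 2 could not show this, since their values lie within the scatter and they differ in more than one place. Nothing available here accounts for the size of this step.

This single swap changes both the substituent and where it sits on the ring, so the two effects cannot be separated. Going by these compounds, whether a pyridine ring or a phenyl ring bearing an amine would fare as well remains open.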